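The source may report more compounds than this note shows. Statements on the series, on what has been measured and on what is new or still open speak of the compounds shown alone.

Within the data shown here, the three compounds measured so far share one core and differ only in the group attached on an aromatic carbon of the ring that also bears the trifluoromethyl group. Compound 1 `O=S(=O)(Nc1nccs1)c1ccc2c(c1)OCC[C@H]2c1ccc(C(F)(F)F)cc1-n1ccnn1` carries a 1H-1,2,3-triazol-1-yl there, and in a physicochemical assay for solubility (on this read-out lower numbers stand for lower solubility and higher numbers for higher solubility), compound 1 gives 154000 nM. Compound 2 `Cc1nc(-c2cc(C(F)(F)F)ccc2[C@@H]2CCOc3cc(S(=O)(=O)Nc4nccs4)ccc32)co1` carries a 2-methyl-1,3-oxazol-4-yl instead; in this assay compound 2 gives 130000 nM, the second highest of the three numbers, with compound 1 nearest and compound 3 furthest. Compound 3 `Cn1nccc1-c1cc(C(F)(F)F)ccc1[C@H]1CCOc2cc(S(=O)(=O)Nc3nccs3)ccc21` gives 83000 nM in this assay. Among the measured compounds shown here, the one step between directly comparable compounds, a 1.2-fold lower number from compound 1 to compound 2 (0.07 log units; within the scatter), stayed within the scatter.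

Compound 4 `O=S(=O)(Nc1nccs1)c1ccc2c(c1)OCC[C@H]2c1ccc(C(F)(F)F)cc1-c1ccc(F)cc1` is the next member: 4-fluorophenyl in place of 2-methyl-1,3-oxazol-4-yl on an aromatic carbon. For the measured compounds named here, only that one measured step bears on this change, and it exchanged one five-membered aromatic ring with hetero atoms for another; no measured step covers the entry of a six-membered aromatic ring of carbon only. Compound 4 is therefore expected to show a step of a 2.4-fold lower number from compound 2 to compound 4 (0.37 log units; beyond the scatter) in this assay, somewhat beyond the scatter but uncertain. The expected value for compound 4 in this assay is 55000 nM, with a range from 18000 nM to 150000 nM.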

Compound 4, solubility: 147000 nM
Compound 4: middle estimate off by 2.7-fold (0.43 log units), on the low side, and the stated range covers the measured number.
By their numbers in this assay, from the lowest: compounds 3, 2, 4 and 1 (each within the scatter of the next).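

Putting 4-fluorophenyl in place of 2-methyl-1,3-oxazol-4-yl on this aromatic carbon gives a 1.1-fold higher number from compound 2 to compound 4 (0.05 log units; within the scatter) in this assay, and putting it in place of 1H-1,2,3-triazol-1-yl gives a 1.0-fold lower number from compound 1 to compound 4 (0.02 log units; within the scatter). The earlier step had only exchanged one five-membered aromatic ring with hetero atoms for another, whereas these two steps show that a six-membered aromatic ring of carbon only, with 0 hydrogen-bond acceptors, also leaves the read-out within the scatter at this place. Nothing given here bears on why the number stays within the scatter across this change.

The compounds shown leave open how this read-out responds when the group at this place is not an aromatic ring, such as an amine, a carboxylic acid or a longer alkyl chain. They also leave open whether plain phenyl would give a number within the scatter of 4-fluorophenyl.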